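Swapping a methoxyphenyl for a difluorophenyl on a shared core

A few compounds are considered here, and "the series" means these few. Any claim that something is new, unique, unknown or untested is made for them only; others in the source may bear on it.

Compound 1 `CCOc1ccc(-c2ccc3ncn(-c4cc(OC)c(OC)c(OC)c4)c3c2)cc1` gives 1710 nM in a functional assay on MCF7 cells (Homo sapiens) for antiproliferative activity, read by MTT assay, with a stated time of 72 h; on this read-out lower numbers stand for stronger inhibition and higher numbers for weaker inhibition.
Compound 2 `COc1ccccc1-c1ccc2ncn(-c3cc(OC)c(OC)c(OC)c3)c2c1` gives 1750 nM in this assay.
Compound 3 `COc1cc(-n2cnc3ccc(-c4ccc(C)cc4F)cc32)cc(OC)c1OC` gives 56 nM in this assay.

Compound 2 holds the highest number of the three. Compound 1 is nearest, with a 1.0-fold higher number from compound 1 to compound 2 (0.01 log units; within the scatter), so the two cannot be told apart. Compound 3 is furthest, reached by a 31-fold lower number from compound 2 to compound 3 (1.49 log units; beyond the scatter).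

Compound 4 `COc1cc(-n2cnc3ccc(-c4cc(F)ccc4F)cc32)cc(OC)c1OC` differs from compound 2 in one place: 2,5-difluorophenyl in place of 2-methoxyphenyl on an aromatic carbon. Among the measured compounds shown here, two measured steps bear on this. The step of a 31-fold lower number from compound 2 to compound 3 (1.49 log units; beyond the scatter) also removed the 2-methoxyphenyl in favour of a ring carrying fluorine, and a 31-fold lower number from compound 1 to compound 3 (1.48 log units; beyond the scatter) ended at the same fluorine-bearing ring from a different start. Both were large and both lowered the number. Compound 3, whose ring carries a methyl as well as a fluorine, reached 56 nM; compound 4 carries fluorine only, so a large but somewhat smaller drop is expected. Compound 4 is therefore estimated at 300 nM, with a range from 80 nM to 1200 nM. The expected step is a 5.8-fold lower number from compound 2 to compound 4 (0.77 log units; beyond the scatter).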

Compound 4, half-maximal inhibitory concentration: 6420 nM
Beside the measured number, compound 4's estimate is 21-fold (1.33 log units) below it, outside the stated range (above it).
By their numbers in this assay, from the lowest: compound 3; then compounds 1 and 2 (each within the scatter of the next); then compound 4.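

In this assay, fluorine on this ring does not by itself lower the number: 2,5-difluorophenyl gives a 3.7-fold higher number from compound 2 to compound 4 (0.56 log units; beyond the scatter), and it likewise gives a 3.8-fold higher number from compound 1 to compound 4 (0.57 log units; beyond the scatter). The large gap lies between the two fluorine-bearing rings, with a 110-fold higher number from compound 3 to compound 4 (2.06 log units; beyond the scatter), so swapping 2-fluoro-4-methylphenyl for 2,5-difluorophenyl matters far more here than the mere presence of fluorine. No measurement in hand explains why these two rings behave so differently.

The compounds shown cannot separate what the methyl and the single fluorine of compound 3 each contribute to its low number. Going by these compounds, how an amine or a carboxylic acid on this ring would behave also stays open.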